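Swapping a furan for isobutyl on a lipophilic amide

The source may report more compounds than this note shows. Statements on the series, on what has been measured and on what is new or still open speak of the compounds shown alone.

Compound 2, with the structure `CC1(C)CC(NC(=O)C(/C=C/[C@@H](NC(=O)OC(C)(C)C)c2ccoc2)(Cc2ccc(F)cc2)Cc2ccc(F)cc2)CC(C)(C)N1`, is the starting point here. In a physicochemical assay for lipophilicity (a higher number here means a more lipophilic compound, a lower number a more polar compound), compound 2 gives 6. Its mirror-image partner compound 3, drawn as `CC1(C)CC(NC(=O)C(/C=C/[C@H](NC(=O)OC(C)(C)C)c2ccoc2)(Cc2ccc(F)cc2)Cc2ccc(F)cc2)CC(C)(C)N1`, gives in this assay a value of 6, and the step of no change at the digits printed from compound 2 to compound 3 (within the scatter) shows no change beyond the scatter, which fits (the fact that compounds 2 and 3 differ only in the configuration as drawn). Together these two compounds hold the highest numbers of the three measured, while compound 1, with the structure `CC(C)C[C@@H](/C=C/C1(C(=O)NC2CC(C)(C)NC(C)(C)C2)CCCC1)NC(=O)OC(C)(C)C`, gives in this assay a lower 4.4; no single-point step links compound 1 to compound 2, so those two values can only be set side by side.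

The new compound 4 has the structure `CC(C)C[C@@H](/C=C/C(Cc1ccc(F)cc1)(Cc1ccc(F)cc1)C(=O)NC1CC(C)(C)NC(C)(C)C1)NC(=O)OC(C)(C)C`. Relative to compound 2 the change is isobutyl in place of furan-3-yl on a saturated chain carbon bound to an amide-type nitrogen and a double-bonded chain carbon. Among the compounds with values here, neither measured step covers this change directly: the only step on record, from compound 2 to compound 3, concerns configuration and was flat. Compound 1 already carries the isobutyl group but differs from compound 2 elsewhere as well, so it offers no clean guide.

The expectation is therefore a modest rise in this assay, a step of a number 0.50 log units higher from compound 2 to compound 4 (beyond the scatter). For compound 4 the estimated value in this assay is 6.5, with a likely range from 5.9 to 7.1.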

Compound 4, partition coefficient: 7.6
For compound 4 the middle estimate is 1.10 log units below the measured one; the whole stated range lies below it.
By their numbers in this assay, from the lowest: compound 1; then compounds 2 and 3 (each within the scatter of the next); then compound 4.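

The earlier pair showed only that redrawing the configuration at this saturated chain carbon, bound to an amide-type nitrogen and a double-bonded chain carbon, leaves the number flat, a step of no change at the digits printed from compound 2 to compound 3 (within the scatter). The new pair shows that the identity of the group on that same carbon does matter in this assay: isobutyl in place of furan-3-yl gives a number 1.60 log units higher from compound 2 to compound 4 (beyond the scatter), so a change at this one place, from a five-membered aromatic ring with a hydrogen-bond acceptor to an open chain with none, can move the value by a large step. Nothing in the data shown explains why the step has this size.

Within the data shown here, still open is whether the flat result for configuration carries over to isobutyl, since only one drawn form of compound 4 appears here, and whether the same swap would give a similar step on the core of compound 1. Also open, from the compounds shown here alone, is how other groups at this place would compare with furan-3-yl and isobutyl, for instance a longer chain such as n-hexyl, an amine or a carboxylic acid.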